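The source may hold more compounds than are shown below. What is called first, only, known or untested is meant among the compounds shown, and "the series" means these compounds.

Compound 1, with the structure `CCC1=C(O)c2c(oc(-c3ccc(C)cc3)cc2=O)C(CC)(CC)C1=O`, is measured in a functional assay on KB cells (Homo sapiens) for antiproliferative activity, read by sulforhodamine B assay, with a stated time of 3 days (on this read-out higher numbers stand for an effect only at larger amounts of compound and lower numbers for an effect already at smaller amounts), where compound 1 gives 39.2 uM. Compound 3, `CCC1=C(O)c2c(oc(-c3ccc(F)cc3)cc2=O)C(CC)(CC)C1=O`, differs from compound 1 by fluoro in place of methyl on an aromatic carbon; in this assay compound 3 gives 33 uM, and the step of a 1.2-fold lower number from compound 1 to compound 3 (0.07 log units; within the scatter) cannot be told from repeat scatter. Compound 2, `CCC1=C(O)c2c(oc(-c3ccc(SC)cc3)cc2=O)C(CC)(CC)C1=O`, carries methylsulfanyl in place of methyl on an aromatic carbon. For compound 2 the measurement in this assay gave only a limit, > 52.1 uM; the step of an at least 1.3-fold higher number from compound 1 to compound 2 (0.12 log units; that floor lies within the scatter) therefore has a floor that also lies within the scatter.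

The untested compound 4, `CCC1=C(O)c2c(oc(-c3ccc(OC)c(C)c3)cc2=O)C(CC)(CC)C1=O`, differs from compound 1 by 4-methoxy-3-methylphenyl in place of 4-methylphenyl on an aromatic carbon. The two measured changes on the same aromatic carbon, to fluoro and to methylsulfanyl, both left the number where it was or nudged it toward weaker effect. The expectation for compound 4 is thus a step of about a 1.1-fold higher number from compound 1 to compound 4 (0.03 log units; within the scatter), not beyond the scatter. The estimate for compound 4 in this assay is 42 uM, between 20 uM and 90 uM.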

Compound 4, concentration for half-maximal effect: 28.5 uM
Compound 4: middle estimate off by 1.5-fold (0.17 log units), on the high side; low and high end bracket the measured number.
By their numbers in this assay, from the lowest: compounds 4, 3 and 1 (each within the scatter of the next). At a limit, above all of these: compound 2.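

Compound 4 shows that this position also accepts a larger group, 4-methoxy-3-methylphenyl, with 9 heavy atoms instead of 7 and a hydrogen-bond acceptor, without leaving the scatter: a 1.4-fold lower number from compound 1 to compound 4 (0.14 log units; within the scatter) and a 1.2-fold lower number from compound 3 to compound 4 (0.06 log units; within the scatter). The comparison with the 4-(methylsulfanyl)phenyl group gives an at least 1.8-fold lower number from compound 2 to compound 4 (0.26 log units; that floor lies within the scatter), which is only a floor. Compound 2 remains a limit and not a number in this assay: the limit of > 52.1 uM in this assay, at which 1 of the 4 values shown sits.

On these data alone, whether an amine or a carboxylic acid on this phenyl ring, or a longer chain in place of the methoxy, would move the number beyond the scatter stays open. As far as these compounds go, compound 4 brings the methoxy and the extra methyl together, and their separate shares in its number remain unknown.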